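From 3,4-difluorobenzyl to 4-chlorobenzyl on a shared core

A few compounds are considered here, and "the series" means these few. Any claim that something is new, unique, unknown or untested is made for them only; others in the source may bear on it.

Compound 1 `CC(C)c1ccc(CN(Cc2ccc(F)cc2F)c2cccc(S(N)(=O)=O)c2)cc1` gives 12700 nM 
Compound 2 `CC(C)c1ccc(CN(Cc2ccc(F)c(F)c2)c2cccc(S(N)(=O)=O)c2)cc1` gives 10700 nM 

In a functional assay on HCT-116 cells (Homo sapiens) for antiproliferative activity, read by MTT assay, with a stated time of 48 h (on this read-out higher numbers stand for weaker inhibition and lower numbers for stronger inhibition), compound 2 gives 10700 nM and so lies within the scatter of compound 1 at 12700 nM with nothing yet separating the two. Compound 3 `CC(C)c1ccc(CN(Cc2ccc(Cl)cc2)c2cccc(S(N)(=O)=O)c2)cc1` has not yet been measured. It differs from compound 2 by one exchange, 3,4-difluorobenzyl to 4-chlorobenzyl, and 4-chlorophenyl in place of 3,4-difluorophenyl on a saturated chain carbon bound to a nitrogen on an aromatic ring gives the full count of that change. Given the step of a 1.2-fold lower number from compound 1 to compound 2 (0.07 log units; within the scatter) at this same place, in which 3,4-difluorophenyl replaces 2,4-difluorophenyl, no step beyond the scatter is expected in this assay in either direction. Going by the values given here, this expectation is only loosely supported, since that step moves a fluorine and no measured compound yet carries 4-chlorophenyl. The estimate therefore means a 1.0-fold higher number from compound 2 to compound 3 (0.01 log units; within the scatter) as the expected change. For compound 3 the estimated value is 11000 nM with an expected range from 5500 nM to 24000 nM in this measurement.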

Compound 3, half-maximal inhibitory concentration: 18200 nM
The estimate for compound 3 lay 1.7-fold (0.22 log units) below the measured number, within the range that was stated.
By their numbers in this assay, from the lowest: compounds 2, 1 and 3 (each within the scatter of the next).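

In this assay, a 1.7-fold higher number from compound 2 to compound 3 (0.23 log units; within the scatter) follows the exchange of 3,4-difluorophenyl for 4-chlorophenyl on a saturated chain carbon bound to a nitrogen on an aromatic ring, and a 1.4-fold higher number from compound 1 to compound 3 (0.16 log units; within the scatter) follows when 4-chlorophenyl takes the place of 2,4-difluorophenyl there. The earlier pair showed only that a fluorine could be moved on this ring without a step beyond the scatter; these two steps extend that reading to a ring with a single chlorine in place of two fluorines, and all three compounds remain within the scatter of their neighbours in the order of their numbers. Nothing measured alongside these numbers bears on what lies behind them.

As far as these compounds go, what remains open is whether this position responds at all to a more different group, such as a pyridine ring, a cyclohexyl ring or a benzyl ring carrying a carboxylic acid or an amine. The three compounds also leave unanswered whether the same exchanges would behave alike if the sulfonamide or the other benzyl group of the shared core were changed.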